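The source may hold more compounds than are shown below. What is called first, only, known or untested is meant among the compounds shown, and "the series" means these compounds.

The shared core is that of compound 1 `C[C@H]1N=C2C[C@H]3C[C@H](C3(C)C)[C@@]2(C)OC1=O`, which carries a methyl where compound 4 will carry a 2-carboxyethyl. In an ADME assay on MCF-10A cells (Homo sapiens) for antiproliferative activity, read by sulforhodamine B assay, with a stated time of 48 h (on this read-out higher numbers stand for weaker inhibition and lower numbers for stronger inhibition), compound 1 gives no measurable inhibition and is reported only as the limit > 1800000 nM. Compound 2 `CC(C)(C)OC(=O)NCCCC[C@H]1N=C2C[C@H]3C[C@H](C3(C)C)[C@@]2(C)OC1=O` carries a chain ending in a (tert-butoxycarbonyl)amino group. In this assay compound 2 likewise reaches only the limit > 1300000 nM. Compound 3 `CC(C)(C)OC(=O)NCCC[C@H]1N=C2C[C@H]3C[C@H](C3(C)C)[C@@]2(C)OC1=O` has (tert-butoxycarbonyl)amino in place of ((tert-butoxycarbonyl)amino)methyl. In this assay compound 3 again stops at the limit > 1500000 nM. Going by the values given here, the one step that can be lined up, a step that the two limits leave unreadable from compound 2 to compound 3, cannot be given a size, since both of its ends are limits.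

Compound 4 `CC1(C)[C@H]2CC3=N[C@H](CCC(=O)O)C(=O)O[C@]3(C)[C@@H]1C2` differs from compound 1 by carboxymethyl in place of hydrogen on a saturated chain carbon bound to a saturated ring carbon. Among the compounds with values here, no measured step offers a readable size, and the three limits (the limit of > 1300000 nM in this assay, at which 1 of the 3 values shown sits), the limit of > 1500000 nM in this assay, at which 1 of the 3 values shown sits, and the limit of > 1800000 nM in this assay, at which 1 of the 3 values shown sits, all show no detectable activity at the top of the tested range. The step from compound 1 to compound 4 is therefore expected to stay within the scatter, as a step that the limit leaves unreadable from compound 1 to compound 4. Compound 4 is expected to give 2000000 nM in this assay, with a range from 800000 nM to 6000000 nM, most likely reported again as a limit only.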

Compound 4, half-maximal inhibitory concentration: > 1200000 nM
Compound 4 ended at the assay's limit; the forecaster's own chance of this, stated with the estimate: 90%; the middle value is on the limit's open side.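

In this assay compound 4 gives > 1200000 nM, which is a limit and not a number. Compound 1 is also known only as a limit, so the step between compound 1 and compound 4 cannot be read. The compounds shown leave open whether any group on the shared core gives a measurable value in this assay.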